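Furan and thiophene swaps on the enone chain

The source may report more compounds than this note shows. Statements on the series, on what has been measured and on what is new or still open speak of the compounds shown alone.

Measured so far in an assay for inhibition of DNA topoisomerase 1 (Homo sapiens), with a stated time of 30 min, tested at 100 uM; a lower number here means a weaker effect, a higher number a stronger effect of the compound at the concentration tested:
compound 1 `O=C(/C=C/c1ccco1)c1ccc(OCC2CO2)cc1`: 36.8%
compound 2 `O=C(/C=C/c1cccs1)c1ccc(OCC2CO2)cc1`: 0%
compound 3 `O=C(/C=C/c1ccoc1)c1ccc(OCC2CO2)cc1`: 5.6%

Compound 3 stands second highest of the three numbers. Its nearest neighbour is compound 2, with a number 5.6 percentage points higher from compound 2 to compound 3 (within the scatter), within the scatter; the step from compound 1 is a number 31.2 percentage points lower from compound 1 to compound 3 (beyond the scatter), beyond it. Compound 4 `O=C(/C=C/c1ccsc1)c1ccc(OCC2CO2)cc1` has not been measured; it differs from compound 3 by thiophen-3-yl in place of furan-3-yl on a double-bonded chain carbon bound to a double-bonded chain carbon. Within the data shown here, the only measured exchange of furan for thiophene is a number 36.8 percentage points lower from compound 1 to compound 2 (beyond the scatter), a large fall, though at the other attachment. Compound 3 already sits near the floor, so a further fall of that size cannot appear, and nothing points to a rise. The expected step is therefore a number 2.6 percentage points lower from compound 3 to compound 4 (within the scatter), within the scatter. Compound 4 is estimated at 3%, between 0% and 15%.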

Compound 4, a percentage reported as inhibition, at one concentration (the size of the read-out at that concentration, not a potency): 46.3%
Estimate against measurement, compound 4: 43.3 percentage points below, outside the stated range (above it).
By their numbers in this assay, from the lowest: compounds 2 and 3 (each within the scatter of the next); then compounds 1 and 4 (each within the scatter of the next).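

In this assay the exchange of furan for thiophene has no single direction at this place: a number 40.7 percentage points higher from compound 3 to compound 4 (beyond the scatter) runs against a number 36.8 percentage points lower from compound 1 to compound 2 (beyond the scatter) and so the outcome depends on the attachment. Among the thiophenes, thiophen-3-yl and thiophen-2-yl are far apart, with a number 46.3 percentage points higher from compound 2 to compound 4 (beyond the scatter) and the two high compounds stay unseparated, with a number 9.5 percentage points higher from compound 1 to compound 4 (within the scatter) as the step between them. No supporting data explain this reversal.

On these data alone, whether a phenyl or a pyridin-3-yl group at this place would keep the read-out of compound 4 stays open. The read-out comes from one concentration only, and it tells a stronger or weaker effect at that concentration and nothing more.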